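The source may hold more compounds than are shown below. What is called first, only, known or untested is meant among the compounds shown, and "the series" means these compounds.

Compound 1 `O=C(Cc1csc2nc(-c3ccc(Br)cc3)cn12)N/N=C/c1ccccc1`: 37200 nM
Compound 2 `COc1cccc(OC)c1/C=N/NC(=O)Cc1csc2nc(-c3ccc(Br)cc3)cn12`: 8130 nM

Both values come from a functional assay on MOLT-4 cells (Homo sapiens) for inhibition, read by sulforhodamine B assay, with a stated time of 48 h (a lower number here means a stronger inhibitor of growth, a higher number a weaker inhibitor of growth), and, of the two, compound 2 has the lower number, making it the stronger inhibitor of growth. The next compound, compound 3 `O=C(Cc1csc2nc(-c3ccc(Br)cc3)cn12)N/N=C/c1ccc(Cl)cc1Cl`, carries 2,4-dichlorophenyl in place of 2,6-dimethoxyphenyl on a carbon with a double bond to nitrogen. Among the compounds with values here, only one measured step bears on this place, and it is modest: a 4.6-fold lower number from compound 1 to compound 2 (0.66 log units; beyond the scatter). Compound 3 gives up the group that came with that drop, yet it keeps a substituted ring, so losing part of the gain seems likelier than losing all of it. Within the data shown here, no measured compound carries chlorine, so this expectation is loose. The expected change is a modest rise in the number, a 1.8-fold higher number from compound 2 to compound 3 (0.27 log units; within the scatter). For compound 3 the estimated value is 15000 nM, with an expected range from 4500 nM to 50000 nM.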

Compound 3, concentration for total growth inhibition: 26300 nM
Beside the measured number, compound 3's estimate is 1.8-fold (0.24 log units) below it; the measured number falls inside the stated range.
By their numbers in this assay, from the lowest: compound 2; then compounds 3 and 1 (each within the scatter of the next).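

In this assay, having substituents on the ring at this position does not by itself bring a lower number: putting 2,4-dichlorophenyl in place of 2,6-dimethoxyphenyl gives a 3.2-fold higher number from compound 2 to compound 3 (0.51 log units; beyond the scatter) and so loses much of what compound 2 gained. Against plain phenyl, the same group gives a 1.4-fold lower number from compound 1 to compound 3 (0.15 log units; within the scatter) and cannot be told apart from it. Among these three compounds, then, only 2,6-dimethoxyphenyl stands apart on the carbon with a double bond to nitrogen, and nothing available explains why the two substituted rings differ.

Still open, from the compounds shown here alone, is whether both methoxy groups are needed or one would serve as well. Also unknown is how this position would respond to a ring carrying a hydroxyl group or an amine.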